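Cytotoxicity in liver cells: swapping carboxy for isopropyl

A few compounds are considered here, and "the series" means these few. Any claim that something is new, unique, unknown or untested is made for them only; others in the source may bear on it.

This set measures how toxic each compound is to cultured liver cells in an ADME assay on HepG2 2.2.15 cells (Homo sapiens) for cytotoxicity, read by MTT assay, with a stated time of 8 days; on this read-out higher numbers stand for lower toxicity in this test and lower numbers for higher toxicity in this test. Compound 1 `COCCNc1nc(F)c(-c2nn(Cc3ccc(C#N)cc3)c(=O)c3ccccc23)cc1Cl` reaches only the assay limit, > 100000 nM. Compound 2 `Cc1cc(-c2ccc(F)nc2F)nn(Cc2ccc(Cl)cc2)c1=O` gives 83800 nM. Compound 3 `O=C(O)c1cc(-c2ccc(F)nc2F)nn(Cc2ccc(Cl)cc2)c1=O` likewise reaches the assay limit, > 100000 nM, so its value is a limit rather than a number. For the measured compounds named here, the one measured step, an at least 1.1-fold higher number from compound 2 to compound 3 (0.07 log units; that floor lies within the scatter), is therefore a floor that lies within the scatter, and the limit of > 100000 nM in this assay, at which 2 of the 3 values shown sit, shows how much of this small set sits at that limit.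

Compound 4 `CC(C)c1cc(-c2ccc(F)nc2F)nn(Cc2ccc(Cl)cc2)c1=O` differs from compound 3 by isopropyl in place of carboxy on an aromatic carbon. Both neighbours of this change, compound 2 with its methyl and compound 3 with its carboxy, sit near or at the limit, so no step beyond the scatter is expected in this assay. Compound 4 is estimated at 80000 nM, with a range of 30000 nM to 200000 nM. That estimate means an at least 1.2-fold lower number from compound 3 to compound 4 (0.09 log units; that floor lies within the scatter), which is expected to stay within the scatter.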

Compound 4, half-maximal cytotoxic concentration: 56700 nM
Beside the measured number, compound 4's estimate is 1.4-fold (0.15 log units) above it; measured number inside the range.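

In this assay, replacing carboxy with isopropyl removes the hydrogen-bond donor and acceptor at this position, opposite the ring nitrogen, and gives an at least 1.7-fold lower number from compound 3 to compound 4 (0.24 log units; that floor lies within the scatter). Replacing methyl with isopropyl at the same carbon gives a 1.5-fold lower number from compound 2 to compound 4 (0.17 log units; within the scatter). For the compounds shown here, compound 4 thus adds a second exact number to that of compound 2, and among methyl, carboxy and isopropyl here, no step is printed as beyond the scatter, so this position shows no clear sensitivity to the change in these compounds.

As far as these compounds go, whether an amine or a longer chain at this position would give a step beyond the scatter remains open. The true size of any step involving compound 3 also remains open, as its value is only a limit, and the set as a whole stays close to that limit: the limit of > 100000 nM in this assay, at which 2 of the 4 values shown sit.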